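Methylating a phenol: from compound 2 to compound 4

The source may hold more compounds than are shown below. What is called first, only, known or untested is meant among the compounds shown, and "the series" means these compounds.

The compounds share a core in which two aryl groups flank a ketone, one of them carrying a nitro group. In a functional assay on HSC-2 cells (Homo sapiens) for cytotoxicity (a lower number here means that less compound is tolerated, a higher number that more compound is tolerated), compound 1 `COc1cc(/C=C2\CC/C(=C\c3ccc([N+](=O)[O-])cc3)C2=O)cc(OC)c1OC` gives only a limit, > 400000 nM, and not a number; this is the limit of > 400000 nM in this assay, at which 1 of the 3 values shown sits. Compound 2 `COc1cc(/C=C2\CCC/C(=C\c3ccc([N+](=O)[O-])cc3)C2=O)ccc1O` gives 2800 nM, the lowest of the two numbers recorded, and compound 3 `COc1ccc(/C=C2\Cc3ccccc3/C(=C\c3ccc([N+](=O)[O-])cc3)C2=O)cc1` gives 11000 nM, a gap that lies beyond the scatter of repeated measurements. Compound 4 `COc1ccc(/C=C2\CCC/C(=C\c3ccc([N+](=O)[O-])cc3)C2=O)cc1OC` has not yet been measured. It differs from compound 2 by a single change: methyl in place of hydrogen on an oxygen on an aromatic ring, so that the hydroxy of compound 2 becomes a methoxy. Among the measured compounds shown here, no measured pair in this set isolates that change, so the direction rests on the values of compound 2 and compound 3 alone, where the methoxy-bearing compound 3 sits higher. The step from compound 2 to compound 4 is expected to be modest and upward, a 2.1-fold higher number from compound 2 to compound 4 (0.33 log units; beyond the scatter). Compound 4 is therefore estimated at 6000 nM, with a likely range from 2000 nM to 20000 nM.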

Compound 4, half-maximal cytotoxic concentration: 2300 nM
Estimate against measurement, compound 4: 2.6-fold (0.42 log units) above; low and high end bracket the measured number.
By their numbers in this assay, from the lowest: compounds 4 and 2 (each within the scatter of the next); then compound 3. At a limit, above all of these: compound 1.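

Among the compounds shown here, the first single-change pair in this assay shows a 1.2-fold lower number from compound 2 to compound 4 (0.09 log units; within the scatter), so compound 2 and compound 4 cannot be told apart in this assay. For the compounds shown here, with methyl in place of hydrogen on an oxygen on an aromatic ring, turning hydroxy into methoxy, the free hydroxy of compound 2 is therefore not required for a value in this range, something the earlier compounds, which differ in more than one place, could not show. No measurement shown offers a reason for this result.

As far as these compounds go, this rests on one pair of compounds, so it remains open whether the same change would give a similar step on the cores of compound 1 or compound 3. From the compounds shown here alone, it is also open how a longer chain on that oxygen, or an amine in place of the hydroxy, would behave.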